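A few compounds are considered here, and "the series" means these few. Any claim that something is new, unique, unknown or untested is made for them only; others in the source may bear on it.

Of the compounds shown here, three that share one core have been tested in a functional assay for inhibition, with Rattus norvegicus as the target; a lower number here means a stronger inhibitor, a higher number a weaker inhibitor. Compound 2 `CC(C)(C)/N=c1\c(O)c(O)\c1=N/Cc1ccc(F)cc1` gives 1500 nM in this assay. Compound 1 `CC(C)(C)/N=c1\c(O)c(O)\c1=N/Cc1ccc(F)cc1Cl` differs from compound 2 by chloro in place of hydrogen on an aromatic carbon, and in this assay compound 1 gives 1400 nM; the step of a 1.1-fold lower number from compound 2 to compound 1 (0.03 log units; within the scatter) shows that this change made no real difference. Compound 3 `CCC(C)(C)/N=c1\c(O)c(O)\c1=N/Cc1ccc(F)cc1` differs from compound 2 by methyl in place of hydrogen on a saturated chain carbon, two bonds along the chain from a double-bonded nitrogen, and in this assay compound 3 gives 360 nM; the step of a 4.2-fold lower number from compound 2 to compound 3 (0.62 log units; beyond the scatter) is the only one here that lies beyond the scatter, and compound 3 stands lowest of the three measured compounds.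

Compound 4 `CCC(C)(C)/N=c1\c(O)c(O)\c1=N/Cc1ccc(F)c(Cl)c1` has not yet been measured. It differs from compound 3 by chloro in place of hydrogen on an aromatic carbon. The same kind of change, chloro in place of hydrogen on an aromatic carbon, was made from compound 2 to compound 1, where it gave the step of a 1.1-fold lower number from compound 2 to compound 1 (0.03 log units; within the scatter); the cores of the two pairs differ by methyl in place of hydrogen on a saturated chain carbon, two bonds along the chain from a double-bonded nitrogen. The place is not identical, though: in compound 1 the chloro sits ortho to a large group and meta to a fluoro group, whereas in compound 4 it sits ortho to a fluoro group and meta to a large group, so the change is of the same kind rather than the same. Because the earlier step of a 1.1-fold lower number from compound 2 to compound 1 (0.03 log units; within the scatter) stayed within the scatter, the step expected for compound 4 is a 1.0-fold lower number from compound 3 to compound 4 (0.01 log units; within the scatter), with the shifted place adding some uncertainty. The estimate for compound 4 in this assay is 350 nM, with a range from 150 nM to 900 nM.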

Compound 4, half-maximal inhibitory concentration: 870 nM
Compound 4: middle estimate off by 2.5-fold (0.40 log units), on the low side; low and high end bracket the measured number.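

In this assay, for the compounds shown here, chloro in place of hydrogen on an aromatic carbon gives a 2.4-fold higher number from compound 3 to compound 4 (0.38 log units; beyond the scatter), whereas the same kind of change on the core of compound 2 made no real difference, yet the two steps cannot be told apart: the same change on two cores in this assay, a 1.1-fold lower number (0.03 log units; within the scatter) from compound 2 to compound 1 and a 2.4-fold higher number (0.38 log units; beyond the scatter) from compound 3 to compound 4, 2.6-fold (0.41 log units) apart, within the scatter of two such steps The series therefore gives no firm sign that the change behaves differently on the two cores, though this agreement within the scatter does not prove that the step carries over unchanged, as only two pairs are available and they point in opposite directions. In compound 4 the chloro also sits ortho to a fluoro group and meta to a large group, which is not the place it holds in compound 1, so the core and the place of the chloro vary together and their contributions cannot be separated.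

The compounds shown leave open how a chloro group would behave in each of these two places on one and the same core. They also leave open whether a bromo or methoxy group on the aromatic ring, or a longer chain on the saturated side, would follow the same course.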